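Replacing the 4-nitrophenyl group of compound 3

The source may report more compounds than this note shows. Statements on the series, on what has been measured and on what is new or still open speak of the compounds shown alone.

Three compounds with a shared core, differing in the group on a carbonyl carbon, have been measured in a functional assay on liver (Rattus norvegicus, strain Sprague-Dawley) for inhibition, with a stated time of 1 h; a higher number here means a weaker inhibitor, a lower number a stronger inhibitor. There, compound 1 (`COc1ccc(C(=O)OCC2Oc3ccc([C@H]4Oc5cc(O)cc(O)c5C(=O)[C@@H]4O)cc3OC2c2ccc(O)c(OC)c2)cc1`) gives 21000 nM, compound 2 (`COc1cc(C2Oc3cc([C@H]4Oc5cc(O)cc(O)c5C(=O)[C@@H]4O)ccc3OC2COC(=O)c2cc(OC)c(OC)c(OC)c2)ccc1O`) gives 25700 nM and compound 3 (`COc1cc(C2Oc3cc([C@H]4Oc5cc(O)cc(O)c5C(=O)[C@@H]4O)ccc3OC2COC(=O)c2ccc([N+](=O)[O-])cc2)ccc1O`) gives 12600 nM. Compound 3 cannot be told apart from compound 1, and it separates, modestly, only from compound 2.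

Compound 4 (`CCOC(=O)CC(=O)OCC1Oc2ccc([C@H]3Oc4cc(O)cc(O)c4C(=O)[C@@H]3O)cc2OC1c1ccc(O)c(OC)c1`) has (ethoxycarbonyl)methyl in place of 4-nitrophenyl on a carbonyl carbon.

Within the data shown here, three measured steps bear on this change. Two stay inside the scatter, a 1.2-fold higher number from compound 1 to compound 2 (0.09 log units; within the scatter) and a 1.7-fold lower number from compound 1 to compound 3 (0.22 log units; within the scatter), while a 2.0-fold lower number from compound 2 to compound 3 (0.31 log units; beyond the scatter) just clears it. All three swap one ring-bearing group for another, so none shows what happens when the ring is lost, and that widens the uncertainty. With steps this small, no shift beyond the scatter is expected in this assay, and the expected step is a 1.4-fold higher number from compound 3 to compound 4 (0.15 log units; within the scatter). For compound 4 the estimated value is 18000 nM, with an expected range from 8000 nM to 42000 nM.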

Compound 4, half-maximal inhibitory concentration: 33400 nM
Estimate against measurement, compound 4: 1.9-fold (0.27 log units) below, within the range that was stated.
By their numbers in this assay, from the lowest: compounds 3, 1, 2 and 4 (each within the scatter of the next, the first and the last beyond it).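

Among these compounds, compound 4 is the only one here whose group on this carbonyl carbon has no ring, and in this assay replacing 4-nitrophenyl with (ethoxycarbonyl)methyl makes it a modestly weaker inhibitor (a 2.7-fold higher number from compound 3 to compound 4 (0.42 log units; beyond the scatter)). Against the other two ring-bearing groups, the same ring-free group stays inside the scatter (a 1.3-fold higher number from compound 2 to compound 4 (0.11 log units; within the scatter) and a 1.6-fold higher number from compound 1 to compound 4 (0.20 log units; within the scatter)), so losing the ring separates compound 4 only from compound 3. No measurement is available to explain this difference.

As far as these compounds go, it remains open whether a ring-free group can match compound 3 at this position. A carboxylic acid, an amine or a longer carbon chain in place of (ethoxycarbonyl)methyl would test this, as would an unsubstituted phenyl in place of 4-nitrophenyl.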